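Series notes: the step from compound 2 to compound 3

A few compounds are considered here, and "the series" means these few. Any claim that something is new, unique, unknown or untested is made for them only; others in the source may bear on it.

Measured compounds:
- compound 1 `CCOC(=O)[C@H](CCC(=O)O)NC(=O)c1ccc(Sc2nc3cc(N)cc(N)c3nc2-c2ccccc2)cc1` gives < 100000 nM
- compound 2 `Nc1cc(N)c2nc(-c3ccccc3)c(Oc3ccc(F)cc3)nc2c1` gives < 100000 nM

In a functional assay on NCI-H460 cells (Homo sapiens) for inhibition, read by sulforhodamine B assay, with a stated time of 48 h (on this read-out lower numbers stand for higher toxicity in this test and higher numbers for lower toxicity in this test), compound 1 returns only a limit, < 100000 nM. Compound 2 likewise returns only a limit in this assay, < 100000 nM. Compound 2 therefore cannot be ranked: both values shown sit at the same limit (the limit of < 100000 nM in this assay, at which 2 of the 2 values shown sit), and no number is known. Compound 3 `COc1ccc(Sc2nc3cc(N)cc(N)c3nc2-c2ccccc2)cc1` differs from compound 2 by (4-methoxyphenyl)sulfanyl in place of 4-fluorophenoxy on an aromatic carbon. Among the compounds with values here, no step between measured compounds is available, so the size of the change in this assay is open; no shift beyond the scatter is assumed in either direction. Compound 3 is expected to give 20000 nM, in the range 2000 nM to 100000 nM, an expected step that the limit leaves unreadable from compound 2 to compound 3.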

Compound 3, concentration lethal to 50% of the cells: < 100000 nM
Compound 3 ended at the assay's limit; the forecaster's own chance of this, stated with the estimate: 40%; the middle value is on the limit's open side.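

Within the data shown here, compound 2 and compound 3 both return only limits in this assay, so no step between them can be read: the limit of < 100000 nM in this assay, at which 3 of the 3 values shown sit.
The compounds shown leave open what actual value each has, and so what (4-methoxyphenyl)sulfanyl in place of 4-fluorophenoxy does to the read-out.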